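Selenium substituent swap in a quinazoline series on RKO cells

A few compounds are considered here, and "the series" means these few. Any claim that something is new, unique, unknown or untested is made for them only; others in the source may bear on it.

Measured compounds:
compound 1, `C[Se]c1ccc(N(C)c2nc(C3CC3)nc3ccccc23)cc1`, 21 nM
compound 2, `Cc1nc(N(C)c2ccc([Se]C#N)c(Cl)c2)c2ccccc2n1`, 11 nM
compound 3, `C[Se]c1ccc(N(C)c2nc(C)nc3ccccc23)cc1Cl`, 4 nM

In a functional assay on RKO cells (Homo sapiens) for inhibition, read by MTT assay, with a stated time of 48 h (on this read-out higher numbers stand for weaker inhibition and lower numbers for stronger inhibition), three compounds have been measured. Compound 3 gives 4 nM, the lowest of the three numbers. Compound 2 differs from compound 3 in one place, and this change, (cyano in place of methyl on a selenium), made a step of a 2.8-fold higher number from compound 3 to compound 2 (0.44 log units; beyond the scatter). Compound 1 gives 21 nM; its number stands within the scatter of compound 2 and beyond the scatter of compound 3. The difference between the core of compound 1 and the core of compound 3 is not broken down here.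

Compound 4, `CN(c1ccc([Se]C#N)cc1)c1nc(C2CC2)nc2ccccc12`, is not yet measured. It differs from compound 1 by cyano in place of methyl on a selenium, the same change that was made from compound 3 to compound 2, and the place is the same. Compound 4 is expected to show a step of a 2.6-fold higher number from compound 1 to compound 4 (0.42 log units; beyond the scatter) in this assay, resting on the step of a 2.8-fold higher number from compound 3 to compound 2 (0.44 log units; beyond the scatter) seen for the same change. Compound 4 is therefore estimated at 55 nM, between 20 nM and 150 nM.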

Compound 4, half-maximal inhibitory concentration: 51 nM
Compound 4: middle estimate off by 1.1-fold (0.03 log units), on the high side; measured number inside the range.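

In this assay, cyano in place of methyl on a selenium gave a 2.4-fold higher number from compound 1 to compound 4 (0.39 log units; beyond the scatter). Set beside the earlier step, the change carried over from one core to the other with no difference beyond the scatter: the same change on two cores in this assay, a 2.8-fold higher number (0.44 log units; beyond the scatter) from compound 3 to compound 2 and a 2.4-fold higher number (0.39 log units; beyond the scatter) from compound 1 to compound 4, 1.1-fold (0.05 log units) apart, within the scatter of two such steps This rests on a single pair of compounds for each core, so it shows the step holding on these two cores only; it does not show that the step would hold on any other core, and it gives no reason why the number rises.

The compounds shown carry only methyl and cyano on the selenium, which leaves open what a longer chain, a trifluoromethyl group or an amine-bearing chain would do in that place. Among the compounds shown here, they also leave open how the ways in which the core of compound 1 differs from the core of compound 3 each contribute, since no pair here separates them.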